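Swapping Methylsulfonyl for Diethylsulfamoyl on a Shared Core

The source may hold more compounds than are shown below. What is called first, only, known or untested is meant among the compounds shown, and "the series" means these compounds.

Compound 1 `Cc1ccc(S(=O)(=O)N(C)CC(C)C)cc1C#Cc1cc(Cl)ccc1OCC(=O)O` gives 4.2 nM in an assay on CHO cells for displacement of a labelled ligand from prostaglandin D2 receptor 2 (Homo sapiens), read by scintillation counting; a lower number here means a stronger inhibitor, a higher number a weaker inhibitor.
Compound 2 `Cc1ccc(S(=O)(=O)N(C)CCCN(C)C)cc1C#Cc1cc(Cl)ccc1OCC(=O)O` gives 287 nM in this assay.
Compound 3 `Cc1ccc(S(C)(=O)=O)cc1C#Cc1cc(Cl)ccc1OCC(=O)O` gives 5 nM in this assay.

Compound 3 stands second highest of the three numbers. Its nearest neighbour is compound 1, with a 1.2-fold higher number from compound 1 to compound 3 (0.08 log units; within the scatter), a step within the scatter; its furthest is compound 2, with a 57-fold lower number from compound 2 to compound 3 (1.76 log units; beyond the scatter), a large step. Compound 4 `CCN(CC)S(=O)(=O)c1ccc(C)c(C#Cc2cc(Cl)ccc2OCC(=O)O)c1` differs from compound 3 in one place: diethylamino in place of methyl on a sulfonyl sulfur.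

Going by the values given here, two measured steps bear on this. The step of a 68-fold higher number from compound 1 to compound 2 (1.83 log units; beyond the scatter) shows a large loss when a 2-(dimethylamino)ethyl replaces isopropyl on the chain carbon bound to the sulfonamide nitrogen. In contrast, a 1.2-fold higher number from compound 1 to compound 3 (0.08 log units; within the scatter) shows that exchanging isobutyl(methyl)amino for methyl on the sulfonyl sulfur changes almost nothing. Diethylamino is a simple dialkylamino group like that of compound 1, not the dimethylaminopropyl-bearing group of compound 2, so only a small step is expected: no change at the digits printed from compound 3 to compound 4 (within the scatter). Compound 4 is therefore estimated at about 5 nM, with a likely range from 2 nM to 15 nM.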

Compound 4, inhibition constant: 3.4 nM
Beside the measured number, compound 4's estimate is 1.5-fold (0.17 log units) above it; measured number inside the range.
By their numbers in this assay, from the lowest: compounds 4, 1 and 3 (each within the scatter of the next); then compound 2.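

In this assay, the step of a 1.5-fold lower number from compound 3 to compound 4 (0.17 log units; within the scatter) shows that this sulfonyl sulfur accepts diethylamino, with 5 heavy atoms, as readily as methyl, with 1 heavy atom. With a 1.2-fold lower number from compound 1 to compound 4 (0.09 log units; within the scatter) as well, three different groups on this sulfur now give readings that cannot be told apart, so neither the size of the group nor the presence of a simple dialkylamino group separates these compounds. Compound 2 stays apart, with an 84-fold lower number from compound 2 to compound 4 (1.93 log units; beyond the scatter) showing that the large loss belongs to its (3-(dimethylamino)propyl)(methyl)amino group. No measurement here explains that gap.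

The compounds shown cannot say whether the loss comes from the longer chain itself or from the amine at its end, a question that the same chain ending in a hydroxyl group could address. As far as these compounds go, how a piperidine ring on this sulfur would read also remains open.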